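The source may report more compounds than this note shows. Statements on the series, on what has been measured and on what is new or still open speak of the compounds shown alone.

Measured so far in a functional assay on SW 1116 cells (Homo sapiens) for antiproliferative activity, read by MTT assay, with a stated time of 24 h; on this read-out lower numbers stand for stronger inhibition and higher numbers for weaker inhibition:
- compound 1 `Cc1ccc(CSc2nnc(-c3ccc4c(c3)OCCO4)n2-c2ccccc2)cc1`: 16200 nM
- compound 2 `Fc1ccccc1CSc1nnc(-c2ccc3c(c2)OCCO3)n1-c1ccccc1`: 13600 nM

Compound 2, at 13600 nM, cannot be told apart from compound 1 on these numbers. Compound 3 `Brc1cccc(CSc2nnc(-c3ccc4c(c3)OCCO4)n2-c2ccccc2)c1` differs from it as follows: 3-bromophenyl in place of 2-fluorophenyl on a saturated chain carbon bound to a sulfur. In words, 3-bromophenyl stands in place of 2-fluorophenyl on a saturated chain carbon bound to a sulfur. Within the data shown here, only one measured step bears on this place: a 1.2-fold lower number from compound 1 to compound 2 (0.08 log units; within the scatter), when 2-fluorophenyl replaced 4-methylphenyl. In this assay, no step beyond the scatter is therefore expected. The estimated step is a 1.0-fold higher number from compound 2 to compound 3 (0.01 log units; within the scatter). Compound 3 is expected at 14000 nM, with an estimated range of 6000 nM to 32000 nM.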

Compound 3, half-maximal inhibitory concentration: 26200 nM
Compound 3: middle estimate off by 1.9-fold (0.27 log units), on the low side; measured number inside the range.
By their numbers in this assay, from the lowest: compounds 2, 1 and 3 (each within the scatter of the next).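

With a third aromatic group on the saturated chain carbon bound to a sulfur, the steps in this assay still stay within the usual scatter (a 1.9-fold higher number from compound 2 to compound 3 (0.28 log units; within the scatter); a 1.6-fold higher number from compound 1 to compound 3 (0.21 log units; within the scatter)). On these numbers, 2-fluorophenyl, 4-methylphenyl and 3-bromophenyl cannot be told apart at this position. No measurement is available to explain these numbers.

From the compounds shown here alone, because 2-fluorophenyl and 3-bromophenyl differ in both halogen and ring position, the effect of each alone stays open; 3-fluorophenyl would separate them. Going by these compounds, whether an amine or a carboxylic acid at this position would give a step beyond the scatter is also open.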